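Methyl to Methoxy: Estimating Efficacy for Compound 3

A few compounds are considered here, and "the series" means these few. Any claim that something is new, unique, unknown or untested is made for them only; others in the source may bear on it.

Measured so far:
compound 1, `Cc1ccccc1-n1nc(C)c2c1NC(=O)[C@H](C)S[C@@H]2c1ccc(Oc2ccccc2)cc1`: 118%
compound 2, `CCOc1cccc(-c2ccc([C@H]3S[C@@H](C)C(=O)Nc4c3c(C)nn4-c3ccccc3C)cc2)c1`: 13%

In an assay on isolated protein for agonist activity at Bile acid receptor (Homo sapiens), read by AlphaScreen, with a stated time of 30 min (on this read-out lower numbers stand for smaller maximal responses and higher numbers for larger maximal responses), compound 1 stands highest of the two measured compounds, with compound 2 far beneath it. Among the measured compounds shown here, the single measured step, a number 105 percentage points lower from compound 1 to compound 2 (beyond the scatter), exchanges phenoxy for 3-ethoxyphenyl on an aromatic carbon, and that exchange sits on a different part of the molecule from the change considered here.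

Compound 3, `COc1ccccc1-n1nc(C)c2c1NC(=O)[C@H](C)S[C@@H]2c1ccc(Oc2ccccc2)cc1`, differs from compound 1 by methoxy in place of methyl on an aromatic carbon. For the measured compounds named here, no measured step touches that position, so the data give no direct guide, and the only measured step concerns another ring. With nothing pointing either way, the step is expected to stay within the scatter: a number 13 percentage points lower from compound 1 to compound 3 (beyond the scatter). Compound 3 is therefore estimated at 105%, within a range from 65% to 130%.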

Compound 3, largest response reached (reported as efficacy), in percent of the reference or control that the assay uses: 37%
The estimate for compound 3 lay 68 percentage points above the measured number, outside the stated range (below it).
By their numbers in this assay, from the lowest: compound 2; then compound 3; then compound 1.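

Going from 2-methylphenyl to 2-methoxyphenyl gives a number 81 percentage points lower from compound 1 to compound 3 (beyond the scatter) in this assay, so the group on this aromatic carbon, ortho to a large group, has a strong bearing on the maximal response. Until now, only the exchange of phenoxy for 3-ethoxyphenyl had been seen to change the number, and compound 1 now stands above both of its single-change neighbours, one altered on each of two different parts of the molecule. Nothing available explains why methoxy gives so much less response than methyl here.

The compounds shown leave open how other groups in this place, such as ethyl, chlorine or an amine, would compare with methyl and methoxy. They also leave open whether methoxy would have a similar effect on a molecule carrying 3-ethoxyphenyl instead of phenoxy.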